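The compounds below may be only part of what the source reports. "The series", "measured", "known", "first", "only" and "open" are said of these compounds alone.

The measured compounds and their values:

compound 1, `Oc1cccc(N2CCNCC2)n1` — > 300 mg/kg
compound 2, `CCOc1cccc(N2CCNCC2)n1` — 30 mg/kg
compound 3, `CC(C)Oc1cccc(N2CCNCC2)n1` — 30 mg/kg

In a functional assay on the whole organism with Mus musculus as the target, in the maximal electroshock model, with a stated time of 30 min (a higher number here means that more compound is needed for the effect, a lower number that less compound is needed), compound 1 gives only > 300 mg/kg, which is a limit of the assay and not a number (the limit of > 300 mg/kg in this assay, at which 1 of the 3 values shown sits). Compound 2 gives 30 mg/kg in this assay, and compound 3 gives 30 mg/kg. Both steps away from compound 1 are clear: an at least 10-fold lower number from compound 1 to compound 2 (1.00 log units; beyond the scatter) and an at least 10-fold lower number from compound 1 to compound 3 (1.00 log units; beyond the scatter). Between the two alkylated compounds there is no difference worth noting: no change at the digits printed from compound 2 to compound 3 (within the scatter).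

Compound 4, `c1cc(OCC2CC2)nc(N2CCNCC2)c1`, is the next member of this set. It differs from compound 1 in one place: cyclopropylmethyl in place of hydrogen on an oxygen on an aromatic ring. The two measured steps from compound 1, to the ethyl and to the isopropyl compound, both bear on it, and both reached the same lower number. A further carbon-only group on the same oxygen is expected to behave in the same way, so a lowering step is expected: an at least 10-fold lower number from compound 1 to compound 4 (1.00 log units; beyond the scatter). Compound 4 is therefore expected to give about 30 mg/kg in this assay, with a range from 10 mg/kg to 100 mg/kg; whether it lands nearer to compound 2 and compound 3 or drifts a little from them is what the measurement will tell.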

Compound 4, minimum effective dose: 10 mg/kg
Compound 4: middle estimate off by 3.0-fold (0.48 log units), on the high side; the measured number falls inside the stated range.
By their numbers in this assay, from the lowest: compound 4; then compounds 2 and 3 (each within the scatter of the next). At a limit, above all of these: compound 1.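

Up to now the groups on this oxygen on an aromatic ring had given one number, with ethyl in compound 2 and isopropyl in compound 3 showing no change, but cyclopropylmethyl separates from both in this assay, with a 3.0-fold lower number from compound 2 to compound 4 (0.48 log units; beyond the scatter) and a 3.0-fold lower number from compound 3 to compound 4 (0.48 log units; beyond the scatter). The carbon-only groups at this place are therefore not interchangeable, and among the compounds shown the one carrying the three-membered ring needs the least compound, with an at least 30-fold lower number from compound 1 to compound 4 (1.47 log units; beyond the scatter). The value of compound 1 is a limit of the assay and not a number, so that last step can only be read as a minimum: the limit of > 300 mg/kg in this assay, at which 1 of the 4 values shown sits.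

As far as these compounds go, what stays open is whether the gain belongs to the three-membered ring itself or merely to a larger group on the oxygen, a question that a straight butyl chain or a cyclobutylmethyl group at the same place would address. Also open, from the compounds shown here alone, is how a group carrying an amine or a carboxylic acid would read on this oxygen, and whether the order among compound 2, compound 3 and compound 4 holds for other changes to the shared core.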